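The source may hold more compounds than are shown below. What is called first, only, known or untested is meant among the compounds shown, and "the series" means these compounds.

Measured compounds:
- Compound 1, `NC(=O)C1CCN1Cc1ccc(OCc2cccc(F)c2)cc1`: 18000 nM
- Compound 2, `C#CCN(Cc1ccc(OCc2cccc(F)c2)cc1)[C@@H](C)C(N)=O`: 7790 nM
- Compound 3, `C[C@H](NCc1ccc(OCc2cccc(F)c2)cc1Cl)C(N)=O`: 12000 nM

All three were tested in an assay on Sf9 cells for inhibition of Amine oxidase [flavin-containing] A (Homo sapiens), with stated times of 15 min and 60 min; on this read-out higher numbers stand for weaker inhibition and lower numbers for stronger inhibition. Compound 1 gives the highest of the three numbers. Compound 3 sits close to it, and the gap between them lies within the scatter of repeated measurements, so the two cannot be told apart. Compound 2 gives a lower number than compound 1, and that gap lies beyond the scatter, so compound 2 does inhibit more strongly than compound 1.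

Compound 4, `NC(=O)C1CN(Cc2ccc(OCc3cccc(F)c3)cc2)C1`, has not yet been measured. It is built from the same atoms as compound 1, joined differently: 3-carbamoylazetidin-1-yl in place of 2-carbamoylazetidin-1-yl on a saturated chain carbon bound to an aromatic carbon. The carboxamide thus moves from one position of the four-membered ring to another, while the rest of the molecule stays the same.

Going by the values given here, no measured pair shows this kind of move, so there is no step to lean on. The expectation is for no change beyond the scatter in this assay, in either direction. Compound 4 is therefore estimated at 15000 nM, with a range from 5000 nM to 45000 nM, which means an expected step of a 1.2-fold lower number from compound 1 to compound 4 (0.08 log units; within the scatter).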

Compound 4, half-maximal inhibitory concentration: > 10000 nM
Compound 4: a limit, no number; the forecaster's own chance of this, stated with the estimate: 15%; the middle value is on the limit's open side.
By their numbers in this assay, from the lowest: compounds 2, 3 and 1 (each within the scatter of the next, the first and the last beyond it).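

In this assay compound 4 gives only a limit and not a number, so no step from compound 1 to compound 4 can be read: the limit of > 10000 nM in this assay, at which 1 of the 4 values shown sits.

The compounds shown leave open whether 3-carbamoylazetidin-1-yl in place of 2-carbamoylazetidin-1-yl changes the inhibition at all, in either direction.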